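Swapping Methyl for Phenyl on the Piperazine Nitrogen

The compounds below may be only part of what the source reports. "The series", "measured", "known", "first", "only" and "open" are said of these compounds alone.

Compound 3 `CN1CCN(CC(=O)Nc2ccc(-c3nc(-c4ccccc4)c(-c4ccccc4)n3C)cc2)CC1` gives 46.2% in a functional assay on MCF7 cells (Homo sapiens) for cytotoxicity, read by MTT assay, with a stated time of 24 h, tested at 32 ug/mL (on this read-out lower numbers stand for a weaker effect and higher numbers for a stronger effect at the one concentration tested), the lowest of the three numbers measured. Compound 1 `Cn1cnnc1SCC(=O)Nc1ccc(-c2nc(-c3ccccc3)c(-c3ccccc3)n2C)cc1` gives 89.2% and compound 2 `Cn1nnnc1SCC(=O)Nc1ccc(-c2nc(-c3ccccc3)c(-c3ccccc3)n2C)cc1` gives 77.5%; the steps of a number 43 percentage points lower from compound 1 to compound 3 (beyond the scatter) and a number 31.3 percentage points lower from compound 2 to compound 3 (beyond the scatter) are both large, while a number 11.7 percentage points lower from compound 1 to compound 2 (beyond the scatter) is modest. Compound 4 `Cn1c(-c2ccc(NC(=O)CN3CCN(c4ccccc4)CC3)cc2)nc(-c2ccccc2)c1-c1ccccc1` differs from compound 3 in one place: phenyl in place of methyl on an amine nitrogen in a ring. Among the compounds with values here, each measured step replaces the whole group on the saturated chain carbon bound to the carbonyl carbon, not that ring nitrogen, so no measured step bears directly on this change and its size cannot be read from them. For compound 4 the estimate is 50%, with a range from 25% to 75%, meaning an expected step of a number 3.8 percentage points higher from compound 3 to compound 4 (within the scatter) that may well lie within the scatter.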

Compound 4, a percentage reported as activity, at one concentration (the size of the read-out at that concentration, not a potency): 63.6%
Compound 4: the middle estimate sits 13.6 percentage points below what was measured; measured number inside the range.
By their numbers in this assay, from the lowest: compound 3; then compound 4; then compound 2; then compound 1.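

Phenyl in place of methyl on the amine nitrogen in the ring gives a number 17.4 percentage points higher from compound 3 to compound 4 (beyond the scatter) in this assay, so this far end of the piperazine does affect the read-out. Even so, the 4-phenylpiperazin-1-yl group does not close the gap to the sulfur-linked groups: the change gives a number 13.9 percentage points lower from compound 2 to compound 4 (beyond the scatter) and a number 25.6 percentage points lower from compound 1 to compound 4 (beyond the scatter). Nothing measured here accounts for the rise. Still open, as far as these compounds go, is whether cyclohexyl or benzyl on this nitrogen would match phenyl, and whether a chlorine or methoxy on the added phenyl would shift the number.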